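Sulfonyl-ring substituents in the bis(fluorobenzylidene) series

This account rests on a few compounds, and the source may have more. Where it says the series, first, only, none or still open, it means among the compounds named here.

Values in a functional assay on HepG2 cells (Homo sapiens) for cytotoxicity, read by MTT assay, with a stated time of 24 h (on this read-out higher numbers stand for weaker inhibition and lower numbers for stronger inhibition), measured so far:
compound 1 `Cc1ccc(S(=O)(=O)N2C/C(=C\c3ccccc3F)C(=O)/C(=C/c3ccccc3F)C2)cc1` gives 14200 nM
compound 2 `O=C1/C(=C/c2ccccc2F)CN(S(=O)(=O)c2ccc(Cl)cc2)C/C1=C\c1ccccc1F` gives 10900 nM
compound 3 `O=C1/C(=C/c2cccc(F)c2)CN(S(=O)(=O)c2ccccc2)C/C1=C\c1cccc(F)c1` gives 3400 nM

Compound 3 stands lowest of the three numbers in this assay; compound 2 is the nearest, with a higher number, and compound 1 sits furthest, also higher. Both of those gaps lie beyond the scatter.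

Compound 4 `N#Cc1ccc(S(=O)(=O)N2C/C(=C\c3cccc(F)c3)C(=O)/C(=C/c3cccc(F)c3)C2)cc1` is the next entry in this set. It differs from compound 3 by cyano in place of hydrogen on an aromatic carbon. Within the data shown here, the one measured step that bears on a change at this position is a 1.3-fold lower number from compound 1 to compound 2 (0.11 log units; within the scatter), an exchange of one small group for another on the same sulfonyl-bearing ring, and it stayed within the scatter. Among the measured compounds shown here, no measured step tells what a cyano group does here, nor what the swap from hydrogen to any group at this place does. On this basis no step beyond the scatter is expected in this assay, in either direction, so the expected step is no change at the digits printed from compound 3 to compound 4 (within the scatter). Compound 4 is therefore estimated at 3400 nM, with a range from 1400 nM to 8000 nM.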

Compound 4, half-maximal inhibitory concentration: 2600 nM
For compound 4 the middle estimate is 1.3-fold (0.12 log units) above the measured one, within the range that was stated.
By their numbers in this assay, from the lowest: compounds 4 and 3 (each within the scatter of the next); then compounds 2 and 1 (each within the scatter of the next).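

In this assay, replacing the phenyl on the sulfonyl group with 4-cyanophenyl gives a 1.3-fold lower number from compound 3 to compound 4 (0.12 log units; within the scatter), so this hydrogen-to-cyano change does not move the number beyond the scatter. The series now has a measured step that starts from the unsubstituted phenylsulfonyl compound, and it joins a 1.3-fold lower number from compound 1 to compound 2 (0.11 log units; within the scatter), a chloro-for-methyl exchange on the same sulfonyl-bearing ring of a differently fluorinated pair; neither step lies beyond the scatter. No measurement shown bears on the origin of this result.

Going by these compounds, whether an amine, a carboxylic acid or a longer chain at this place on the ring would also stay within the scatter remains open. Also open, on these data alone, is whether cyano gives a comparable step on the fluorobenzylidene arrangement of compound 1.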